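The source may report more compounds than this note shows. Statements on the series, on what has been measured and on what is new or still open speak of the compounds shown alone.

In an ADME assay on the whole organism (Rattus norvegicus) for pharmacokinetics, using cassette dosing, at a dose of 1 mg/kg by the oral route (a higher number here means that a larger share of the oral dose reaches the circulation, a lower number that a smaller share of the oral dose reaches the circulation), three compounds have been measured:

compound 1, `CC(C)Oc1ccc(Nc2nc(=O)n(CCCO)c(=O)n2Cc2ccc(Cl)cc2)cc1Cl`, gives 36.2%;
compound 2, `C[C@@H](Cn1c(=O)[nH]/c(=N\c2ccc(Oc3nccs3)cc2)n(Cc2ccc(Cl)cc2)c1=O)C(=O)O`, gives 41.4%;
compound 3, `CC(C)Oc1ccc(Nc2nc(=O)n(CCO)c(=O)n2Cc2ccc(Cl)cc2)cc1Cl`, gives 48.1%.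

Compound 2 stands second of the three, with compound 1 below it and compound 3 above it, both within the scatter of its own number. Among the measured compounds shown here, the only step between measured compounds that differ in one place is a number 11.9 percentage points higher from compound 1 to compound 3 (beyond the scatter), and it concerns the saturated chain on the core, not the aryloxy group. Compound 4, `C[C@@H](Cn1c(=O)[nH]/c(=N\c2ccc(Oc3ccccn3)cc2)n(Cc2ccc(Cl)cc2)c1=O)C(=O)O`, differs from compound 2 by pyridin-2-yl in place of 1,3-thiazol-2-yl on an oxygen on an aromatic ring. For the measured compounds named here, no measured step bears on a swap at this place, so in this assay no step beyond the scatter is expected: the estimated step is a number 0.4 percentage points lower from compound 2 to compound 4 (within the scatter). For compound 4 the expected value is 41%, with a range from 25% to 58%.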

Compound 4, oral bioavailability: 52.8%
Beside the measured number, compound 4's estimate is 11.8 percentage points below it; measured number inside the range.
By their numbers in this assay, from the lowest: compounds 1, 2, 3 and 4 (each within the scatter of the next, the first and the last beyond it).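

In this assay, among the compounds shown here, pyridin-2-yl in place of 1,3-thiazol-2-yl on an oxygen on an aromatic ring gives a number 11.4 percentage points higher from compound 2 to compound 4 (beyond the scatter), the first step at this place. The group on this oxygen therefore changes the share of the oral dose reaching the circulation, at least in this pair. Nothing available accounts for the step.

Going by these compounds, whether a phenyl or pyrimidin-2-yl group on the same oxygen would do likewise remains open. So does whether the step would hold with a hydroxy-bearing chain in place of the carboxylic acid chain.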